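The source may report more compounds than this note shows. Statements on the series, on what has been measured and on what is new or still open speak of the compounds shown alone.

Compound 1 `O=C(O)c1ccccc1-c1ccc(CCc2ncc(Cc3ccccc3Cl)[nH]2)cc1`: 22 nM
Compound 2 `CCCCc1cnc(CCc2ccc(-c3ccccc3C(=O)O)cc2)[nH]1`: 93 nM
Compound 3 `O=C(O)c1ccccc1-c1ccc(CCc2ncc(Cc3ccc(F)cc3)[nH]2)cc1`: 50 nM

All three share one core and were tested in an in vitro functional assay on cells for agonist activity at Bombesin receptor subtype-3 (Mus musculus), read by luminescence and calcium flux; a higher number here means that more compound is needed for the effect, a lower number that less compound is needed. Compound 3 shows the second highest number of the three: its gap to compound 2 lies within the scatter, whereas a 2.3-fold higher number from compound 1 to compound 3 (0.36 log units; beyond the scatter) lies beyond it. Compound 4 `COc1ccccc1Cc1cnc(CCc2ccc(-c3ccccc3C(=O)O)cc2)[nH]1` has not yet been measured. 2-methoxyphenyl in place of 4-fluorophenyl on a saturated chain carbon bound to an aromatic carbon The step that bears most on this change is a 2.3-fold higher number from compound 1 to compound 3 (0.36 log units; beyond the scatter), where 2-chlorophenyl gave the lower number than 4-fluorophenyl. The step of a 1.9-fold lower number from compound 2 to compound 3 (0.27 log units; within the scatter) adds nothing beyond the scatter. Because 2-methoxyphenyl resembles 2-chlorophenyl in a 2.3-fold higher number from compound 1 to compound 3 (0.36 log units; beyond the scatter), compound 4 is expected to move to a somewhat lower number, about a 1.7-fold lower number from compound 3 to compound 4 (0.22 log units; within the scatter). Compound 4 is therefore estimated at 30 nM, within a range from 12 nM to 90 nM.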

Compound 4, half-maximal effective concentration: 163 nM
Compound 4: the middle estimate sits 5.4-fold (0.74 log units) below what was measured; measured number above the stated range.
By their numbers in this assay, from the lowest: compound 1; then compounds 3, 2 and 4 (each within the scatter of the next, the first and the last beyond it).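

Chloro and methoxy are not interchangeable at this place on the ring: methoxy in place of chloro gives a 7.4-fold higher number from compound 1 to compound 4 (0.87 log units; beyond the scatter). The 2-methoxyphenyl group also fares worse than 4-fluorophenyl, with a 3.3-fold higher number from compound 3 to compound 4 (0.51 log units; beyond the scatter). Against the propyl group, it shows a 1.8-fold higher number from compound 2 to compound 4 (0.24 log units; within the scatter), so in this assay an aromatic ring at this place does not by itself separate compound 4 from the chain. Nothing shown explains the gap between chloro and methoxy. From the compounds shown here alone, it remains open whether the low number of compound 1 depends on chloro itself, or whether a methyl or bromo group in its place would keep it.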